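From 4-chlorophenyl to 4-methoxyphenyl, an open step

The source may report more compounds than this note shows. Statements on the series, on what has been measured and on what is new or still open speak of the compounds shown alone.

In a functional assay on K562 cells (Homo sapiens) for cytotoxicity, read by MTT assay, with a stated time of 48 h (a higher number here means a weaker inhibitor, a lower number a stronger inhibitor), compound 2 `COc1cc(-n2c(-c3ccc(Br)cc3)cn(C(C)=O)c2=O)cc(OC)c1OC` gives 1000 nM. Compound 3 `COc1cc(-n2c(-c3ccc(Cl)cc3)cn(C(C)=O)c2=O)cc(OC)c1OC` gives > 50000 nM, which is a limit of the assay and not a number. For compound 1 `COc1ccc(-c2c[nH]c(=O)n2-c2cc(OC)c(OC)c(OC)c2)cc1` the result reads "not determined" (no result reported), so it offers no guide. Compound 4 `COc1ccc(-c2cn(C(C)=O)c(=O)n2-c2cc(OC)c(OC)c(OC)c2)cc1` carries methoxy in place of chloro on an aromatic carbon, para to a large group: methoxy in place of chloro on an aromatic carbon. Only an at least 50-fold higher number from compound 2 to compound 3 (1.69 log units; beyond the scatter) bears on this change; it is large and beyond the scatter, so a swap on this aromatic carbon can move the number strongly. A lower number is therefore expected, with an estimated at least 10-fold lower number from compound 3 to compound 4 (1.00 log units; beyond the scatter), though its size remains uncertain. The expected value for compound 4 is 5000 nM, within an estimated range of 400 nM to 50000 nM.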

Compound 4, half-maximal inhibitory concentration: 200 nM
The estimate for compound 4 lay 25-fold (1.40 log units) above the measured number; measured number below the stated range.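

In this assay, methoxy in place of chloro on this aromatic carbon gives an at least 250-fold lower number from compound 3 to compound 4 (2.39 log units; beyond the scatter) and so moves the number strongly in the direction that bromo alone had shown. The value of compound 3 is only a limit of the assay: the limit of > 50000 nM in this assay, at which 1 of the 4 values shown sits. Methoxy in place of bromo gives a 5.0-fold lower number from compound 2 to compound 4 (0.70 log units; beyond the scatter), which makes compound 4 the strongest of the three compounds with a result here, and shows that this place accepts a group other than a halogen.

On these data alone, whether an amine or a longer chain such as ethoxy would hold this number stays open. The compounds shown also do not explain why chloro stands so far from both bromo and methoxy.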